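A few compounds are considered here, and "the series" means these few. Any claim that something is new, unique, unknown or untested is made for them only; others in the source may bear on it.

Measured so far in this study:

compound 1 `COc1ccccc1/C=C(/SCc1ccc(C)cc1)C(=O)c1ccc(Cl)cc1`: 10000 nM
compound 2 `Cc1ccsc1/C=C(/SCc1ccc(Cl)cc1Cl)C(=O)c1ccc(Cl)cc1`: 10000 nM
compound 3 `O=C(/C(=C\c1c(O)cc(O)cc1O)SCc1ccc(Cl)cc1Cl)c1ccc(Cl)cc1`: 25000 nM

In a functional assay on DU-145 cells (Homo sapiens) for inhibition, read by trypan blue exclusion, with a stated time of 96 h (on this read-out higher numbers stand for weaker inhibition of growth and lower numbers for stronger inhibition of growth), compound 3 gives the highest of the three numbers, that is, the weakest growth inhibition, and both other compounds lie at the same distance below it, beyond the scatter. Among the compounds with values here, the one measured step that reaches compound 3 is a 2.5-fold higher number from compound 2 to compound 3 (0.40 log units; beyond the scatter), a modest move.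

Compound 4 `Cc1ccc(CS/C(=C/c2c(O)cc(O)cc2O)C(=O)c2ccc(Cl)cc2)cc1` is the next compound to be measured in this assay. It differs from compound 3 in one place: 4-methylphenyl in place of 2,4-dichlorophenyl on a saturated chain carbon bound to a sulfur. Within the data shown here, no measured pair isolates this change. Compounds 1 and 2 carry the two groups in question, but they also differ in the group on the double-bonded chain carbon, and in this assay compound 1 gives 10000 nM while compound 2 gives 10000 nM, the same number. With the trihydroxyphenyl group kept, the change is therefore expected to produce no step beyond the scatter. Compound 4 is expected to give about 22000 nM, within 8000 nM to 60000 nM. This estimate means an expected step of a 1.1-fold lower number from compound 3 to compound 4 (0.06 log units; within the scatter), inside the usual scatter.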

Compound 4, concentration for 50% growth inhibition: 50000 nM
Compound 4: middle estimate off by 2.3-fold (0.36 log units), on the low side; low and high end bracket the measured number.
By their numbers in this assay, from the lowest: compounds 1 and 2 (each within the scatter of the next); then compounds 3 and 4 (each within the scatter of the next).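

In this assay, the change on the saturated chain carbon bound to a sulfur can now be read on its own: 4-methylphenyl in place of 2,4-dichlorophenyl gives a 2.0-fold higher number from compound 3 to compound 4 (0.30 log units; within the scatter), so this read-out does not separate the two groups when 2,4,6-trihydroxyphenyl is present. The result also tests 2,4,6-trihydroxyphenyl with the 4-methylbenzyl group in place: swapping it in for 2-methoxyphenyl gives a 5.0-fold higher number from compound 1 to compound 4 (0.70 log units; beyond the scatter), weaker growth inhibition in the same direction as a 2.5-fold higher number from compound 2 to compound 3 (0.40 log units; beyond the scatter), where it replaced 3-methylthiophen-2-yl. No evidence is available to explain these numbers.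

The compounds shown leave open whether a benzyl group carrying an amine or a carboxylic acid would move the number beyond the scatter. They also leave open how a phenyl ring with a single hydroxy group would compare with 2,4,6-trihydroxyphenyl.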